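Swapping One Dichlorothiophenyl Group for Another

The source may hold more compounds than are shown below. What is called first, only, known or untested is meant among the compounds shown, and "the series" means these compounds.

compound 1 `O=[N+]([O-])c1ncn(CCCNS(=O)(=O)c2ccc(Cl)s2)n1`: 244000 nM
compound 2 `O=[N+]([O-])c1ncn(CCCCNS(=O)(=O)c2ccc(Cl)s2)n1`: 128000 nM
compound 3 `O=[N+]([O-])c1ncn(CCCNS(=O)(=O)c2cc(Cl)sc2Cl)n1`: 119000 nM

In an ADME assay on L6 cells (Rattus norvegicus) for cytotoxicity, read by resazurin assay, with a stated time of 72 h (on this read-out higher numbers stand for weaker inhibition and lower numbers for stronger inhibition), compound 3, at 119000 nM, cannot be separated from compound 2 and stands clearly lower than compound 1. The next structure, compound 4 `O=[N+]([O-])c1ncn(CCCNS(=O)(=O)c2cc(Cl)c(Cl)s2)n1`, differs from compound 3 only in the group on the sulfonyl sulfur: 4,5-dichlorothiophen-2-yl in place of 2,5-dichlorothiophen-3-yl on a sulfonyl sulfur. For the measured compounds named here, the one measured step that changes this group is a 2.1-fold lower number from compound 1 to compound 3 (0.31 log units; beyond the scatter). That step is modest and only just clears the scatter, so little movement is expected here. The expected result is a 1.1-fold higher number from compound 3 to compound 4 (0.02 log units; within the scatter), with no shift beyond the scatter. Compound 4 is estimated at 125000 nM, with an expected range of 65000 nM to 240000 nM.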

Compound 4, half-maximal inhibitory concentration: 101000 nM
Estimate against measurement, compound 4: 1.2-fold (0.09 log units) above; low and high end bracket the measured number.
By their numbers in this assay, from the lowest: compounds 4, 3, 2 and 1 (each within the scatter of the next, the first and the last beyond it).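

In this assay, exchanging 2,5-dichlorothiophen-3-yl for 4,5-dichlorothiophen-2-yl on the sulfonyl sulfur gives a 1.2-fold lower number from compound 3 to compound 4 (0.07 log units; within the scatter), so these two dichlorothiophene groups cannot be separated on this read-out. The change of chloro in place of hydrogen on an aromatic carbon alone gives a 2.4-fold lower number from compound 1 to compound 4 (0.38 log units; beyond the scatter), showing that this single change is enough to clear the scatter, though only modestly. Nothing available explains either step.

As far as these compounds go, it remains open whether a bromo or methyl group in place of that chloro, or a phenyl ring in place of the thiophene, would move the number.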